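Ester for ketone on a coumarin-type chalcone scaffold

The compounds below may be only part of what the source reports. "The series", "measured", "known", "first", "only" and "open" are said of these compounds alone.

Measured compounds:
Compound 1 `CCC(C)c1cc(C=O)cc2cc(C(C)=O)c(=O)oc12`: "not active" (no number reported)
Compound 2 `CCC(C)c1cc(/C=C/C(=O)c2ccc(Cl)cc2)cc2cc(C(C)=O)c(=O)oc12`: "not active" (no number reported)
Compound 3 `CCOC(=O)c1cc2cc(/C=C/C(=O)c3ccccc3)cc(C(C)CC)c2oc1=O`: 12900 nM

Of the compounds shown here, three have been tested in a functional assay on A549 cells (Homo sapiens) for cytotoxicity, read by sulforhodamine B assay, with a stated time of 48 h; a higher number here means a weaker inhibitor, a lower number a stronger inhibitor. Compound 1 returned "not active" (no number reported) and no single number. Compound 2 likewise returned "not active" (no number reported), so there is no number to place it against the others. Only compound 3, in this assay, gives a number, 12900 nM, which is a weak value on the scale of this read-out.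

The unmeasured compound 4 `CCC(C)c1cc(/C=C/C(=O)c2ccc(Cl)cc2)cc2cc(C(=O)OC)c(=O)oc12` is built from compound 2 by one change: methoxy in place of methyl on a carbonyl carbon. Among the compounds with values here, without a number for compound 2, no step in this assay can be computed, and no pair of measured compounds shares exactly this change. Compound 3 carries a closely related ester at the same place and sits far from potent, so the expected outcome for compound 4 is a weak value, most likely within the scatter of compound 3, with a real chance that this assay again reports no number. For compound 4 the half-maximal inhibitory concentration is estimated at 15000 nM, in a range from 5000 nM to 60000 nM.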

Compound 4, half-maximal inhibitory concentration: 16700 nM
Compound 4: the middle estimate sits 1.1-fold (0.05 log units) below what was measured; low and high end bracket the measured number.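

No step can be read here: in this assay compound 4 gives 16700 nM but compound 2 has no single number to set against it. Nothing measured here offers an explanation for this result. The compounds shown leave open how far acetyl to methoxycarbonyl alone changes cytotoxicity.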